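From Isopropyl to 2-Methylprop-2-en-1-yl at the Ring Amine

This account rests on a few compounds, and the source may have more. Where it says the series, first, only, none or still open, it means among the compounds named here.

Of the compounds shown here, three built on one shared core have been tested in an assay for displacement of a labelled ligand from Sigma non-opioid intracellular receptor 1 (Cavia porcellus), read by scintillation counting, with a stated time of 180 min; on this read-out higher numbers stand for weaker inhibition and lower numbers for stronger inhibition. Compound 1 `COc1ccc(CN2CCC3(CC2)OC(OC)Cc2c3cnn2-c2ccccc2)cc1` gives 1.5 nM. Compound 2 `COC1Cc2c(cnn2-c2ccccc2)C2(CCN(CCCCc3ccccc3)CC2)O1` gives 3.2 nM. Compound 3 `COC1Cc2c(cnn2-c2ccccc2)C2(CCN(CC(C)C)CC2)O1` gives 6.3 nM, the highest number of the three; its gap to compound 2 lies within the scatter, while the step of a 4.2-fold higher number from compound 1 to compound 3 (0.62 log units; beyond the scatter) lies beyond it. The three differ only in the group on a saturated chain carbon bound to the amine nitrogen in the ring, and the steps seen there were modest: a 2.1-fold higher number from compound 1 to compound 2 (0.33 log units; beyond the scatter) and a 2.0-fold higher number from compound 2 to compound 3 (0.29 log units; within the scatter).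

Compound 4 `C=C(C)CCN1CCC2(CC1)OC(OC)Cc1c2cnn1-c1ccccc1` takes the next step from compound 3: 2-methylprop-2-en-1-yl in place of isopropyl on a saturated chain carbon bound to an amine nitrogen in a ring. One small chain is exchanged for another small chain that carries one double bond outside aromatic rings and no ring. Going by the values given here, no measured step matches this exchange exactly. The closest guide is a 2.0-fold higher number from compound 2 to compound 3 (0.29 log units; within the scatter), which stayed within the scatter even though a larger chain gave way to a small one, and the larger phenyl-bearing chains of compound 1 and compound 2 gave the lower numbers. A step of a 1.3-fold lower number from compound 3 to compound 4 (0.10 log units; within the scatter) is therefore expected, within the scatter, leaning slightly toward a lower number. Compound 4 is estimated to give 5 nM, with a range from 2 nM to 13 nM.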

Compound 4, inhibition constant: 1.6 nM
The estimate for compound 4 lay 3.1-fold (0.49 log units) above the measured number, and the stated range ends above it.
By their numbers in this assay, from the lowest: compounds 1, 4, 2 and 3 (each within the scatter of the next, the first and the last beyond it).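

In this assay, going by these compounds alone, this position proves more sensitive to a small change than the earlier compounds suggested: 2-methylprop-2-en-1-yl in place of isopropyl gives a 3.9-fold lower number from compound 3 to compound 4 (0.60 log units; beyond the scatter) even though both chains are small and neither carries a ring. The earlier compounds shown here hinted that the phenyl-bearing chains gave the lower numbers, but compound 4 goes against that pattern, with a 2.0-fold lower number from compound 2 to compound 4 (0.30 log units; within the scatter) and a 1.1-fold higher number from compound 1 to compound 4 (0.03 log units; within the scatter) showing that its small chain without a ring stands level with both compound 2 and compound 1 in this set. Nothing shown here offers an explanation for this step.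

The change adds one carbon and one double bond together, so the compounds shown cannot say which of the two goes with the lower number; 3-methylbutyl, the same chain without the double bond, would separate them. From the compounds shown here alone, how a chain ending in a hydroxyl group or an amine would read at this position also remains open.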